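A few compounds are considered here, and "the series" means these few. Any claim that something is new, unique, unknown or untested is made for them only; others in the source may bear on it.

Measured compounds:
compound 1 `CCSCc1c(C)nc2c(OCc3ccccc3)cccn12` — 36%
compound 2 `Cc1nc2c(OCc3ccccc3)cccn2c1CC(=O)O` — 12%

In a functional assay on the whole organism with Rattus norvegicus as the target, with a stated time of 4 h, at a dose of 40 mg/kg by the intraperitoneal route (a lower number here means less inhibition, a higher number more inhibition at the dose given (going by the name of the read-out)), compound 1 gives 36%, and compound 2 gives 12%. Within the data shown here, compound 2 stands lowest of the two numbers; its nearest neighbour is compound 1, and the single step joining them, a number 24 percentage points lower from compound 1 to compound 2 (beyond the scatter), goes with carboxy in place of ethylsulfanyl on a saturated chain carbon bound to an aromatic carbon.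

Compound 3 `CCCCC(=O)OCc1c(C)nc2c(OCc3ccccc3)cccn12` has not yet been measured in this assay. It differs from compound 2 by (butylcarbonyl)oxy in place of carboxy on a saturated chain carbon bound to an aromatic carbon. Among the measured compounds shown here, the only measured step bears on this change only indirectly: a number 24 percentage points lower from compound 1 to compound 2 (beyond the scatter) shows that introducing carboxy at this place went with a modest fall, and compound 3 removes the carboxy again, replacing it with (butylcarbonyl)oxy. Nothing measured shows the ester itself. On that basis a rise is expected rather than a fall, with size a number 18 percentage points higher from compound 2 to compound 3 (beyond the scatter) expected, of the order of the fall seen in a number 24 percentage points lower from compound 1 to compound 2 (beyond the scatter). For compound 3 the estimated value in this assay is 30%, within an expected range from 10% to 50%.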

Compound 3, a percentage reported as inhibition, in the whole organism at one dose (the size of the read-out at that dose, not a potency): 45%
Beside the measured number, compound 3's estimate is 15 percentage points below it, within the range that was stated.
By their numbers in this assay, from the lowest: compound 2; then compounds 1 and 3 (each within the scatter of the next).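

In this assay, among these compounds, the ester gives the first direct reading of an acyloxy group on a saturated chain carbon bound to an aromatic carbon, and replacing carboxy with (butylcarbonyl)oxy gives a number 33 percentage points higher from compound 2 to compound 3 (beyond the scatter). Against ethylsulfanyl at the same place, the step is a number 9 percentage points higher from compound 1 to compound 3 (within the scatter), so these two groups cannot be told apart in this read-out, and among the three groups shown only carboxy stands apart, with beyond-scatter steps to both of the others. Nothing available explains why the carboxy compound reads differently from the other two.

The compounds shown leave open whether the (butylcarbonyl)oxy reading depends on the length of its butyl chain, which a shorter acetyl ester or a longer chain on the same carbonyl would test, and whether the ester linkage itself matters, which an amide or a free hydroxyl at this place would test. Each number also comes from a single dose and a single time, so this assay gives the size of the read-out at that dose and no potency ranking.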